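This account rests on a few compounds, and the source may have more. Where it says the series, first, only, none or still open, it means among the compounds named here.

Among the compounds with values here, in a functional assay on KG-1 cells (Homo sapiens) for cytotoxicity, read by luminescence and CellTiter-Glo, with a stated time of 3 days (on this read-out higher numbers stand for weaker inhibition and lower numbers for stronger inhibition), compound 1 `N#Cc1ccc(NC(=O)c2cc(-c3ccccc3)ccc2O)cc1` gives 1300 nM, the higher of the two numbers so far, while compound 2 `O=C(Nc1ccc(OC(F)(F)F)c(Cl)c1)c1cc(F)ccc1O` gives 370 nM, a gap beyond the usual scatter. Compound 3 `N#Cc1ccc(NC(=O)c2cc(Cc3ccccc3)ccc2O)cc1` keeps the core of compound 1 and changes it in one place: benzyl in place of phenyl on an aromatic carbon. Within the data shown here, no measured pair shows what such a change does in this assay, so no step beyond the scatter is expected, and no firm direction. The expected change is a 1.1-fold lower number from compound 1 to compound 3 (0.03 log units; within the scatter). For compound 3 the estimated value is 1200 nM, with an expected range of 400 nM to 3500 nM.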

Compound 3, half-maximal inhibitory concentration: 1930 nM
Compound 3: the middle estimate sits 1.6-fold (0.21 log units) below what was measured; low and high end bracket the measured number.
By their numbers in this assay, from the lowest: compound 2; then compounds 1 and 3 (each within the scatter of the next).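

At the aromatic carbon para to a hydroxy group, benzyl in place of phenyl gives a 1.5-fold higher number from compound 1 to compound 3 (0.17 log units; within the scatter) in this assay. Within the data shown here, this is the first reading of a change at this position, and it shows that this swap leaves the number within the scatter, with no firm direction. Nothing measured here bears on why. On these data alone, whether an amine, a carboxylic acid or a longer chain at this carbon would give a step beyond the scatter remains open. So does whether the swap from phenyl to benzyl would behave alike on a different core.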